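This account rests on a few compounds, and the source may have more. Where it says the series, first, only, none or still open, it means among the compounds named here.

The measured compounds:

compound 1, `CC(C)NC(=O)N1CCN(C(=S)SCc2cn(Cc3ccccc3F)nn2)CC1`, 1860 nM
compound 2, `CCN(C)C(=O)N1CCN(C(=S)SCc2cn(Cc3ccccc3F)nn2)CC1`, 7210 nM
compound 3, `COc1ccc(Cn2cc(CSC(=S)N3CCN(C(=O)NC(C)C)CC3)nn2)cc1`, 19600 nM

All three were tested in a functional assay on MCF7 cells (Homo sapiens) for cytotoxicity, read by MTT assay, with a stated time of 72 h; on this read-out higher numbers stand for weaker inhibition and lower numbers for stronger inhibition. Compound 1 gives the lowest of the three numbers, at 1860 nM. Compound 2 differs from it by one change, (ethyl(methyl)amino in place of isopropylamino on a carbonyl carbon), and the result is a 3.9-fold higher number from compound 1 to compound 2 (0.59 log units; beyond the scatter). Compound 3 differs from compound 1 in another place, (4-methoxyphenyl in place of 2-fluorophenyl on a saturated chain carbon bound to an aromatic nitrogen), and there the result is an 11-fold higher number from compound 1 to compound 3 (1.02 log units; beyond the scatter); compound 3 therefore stands highest of the three, with compound 2 the nearer of the other two.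

Compound 4, `CCN(C)C(=O)N1CCN(C(=S)SCc2cn(Cc3ccc(OC)cc3)nn2)CC1`, has not been measured. It differs from compound 3 by ethyl(methyl)amino in place of isopropylamino on a carbonyl carbon. This is the same change that separates compound 1 from compound 2, in the same place, on a carbonyl carbon whose other neighbours are an amide-type nitrogen in a ring. The two pairs differ only in their cores, and how the cores differ is given by 4-methoxyphenyl in place of 2-fluorophenyl on a saturated chain carbon bound to an aromatic nitrogen.

Given that the change gave a 3.9-fold higher number from compound 1 to compound 2 (0.59 log units; beyond the scatter), a step of similar direction and size is expected from compound 3 to compound 4 in this assay, namely a 3.3-fold higher number from compound 3 to compound 4 (0.52 log units; beyond the scatter). Compound 3 already stands at 19600 nM, the highest of the three numbers, so the expected number for compound 4 lies higher still. The estimate for compound 4 is 65000 nM, expected to fall between 22000 nM and 190000 nM.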

Compound 4, half-maximal inhibitory concentration: 21400 nM
Compound 4: the middle estimate sits 3.0-fold (0.48 log units) above what was measured; measured number below the stated range.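

In this assay, ethyl(methyl)amino in place of isopropylamino on the carbonyl carbon gives a 1.1-fold higher number from compound 3 to compound 4 (0.04 log units; within the scatter), so compound 3 and compound 4 cannot be told apart, and the step seen on the core of compound 1 does not carry over to the core of compound 3: the same change on two cores in this assay, a 3.9-fold higher number (0.59 log units; beyond the scatter) from compound 1 to compound 2 and a 1.1-fold higher number (0.04 log units; within the scatter) from compound 3 to compound 4, 3.6-fold (0.55 log units) apart, beyond the scatter of two such steps. Read the other way round, 4-methoxyphenyl in place of 2-fluorophenyl gives a 3.0-fold higher number from compound 2 to compound 4 (0.47 log units; beyond the scatter), which keeps the direction seen with the isopropylamino pair but not its size: the same change on two cores in this assay, an 11-fold higher number (1.02 log units; beyond the scatter) from compound 1 to compound 3 and a 3.0-fold higher number (0.47 log units; beyond the scatter) from compound 2 to compound 4, 3.6-fold (0.55 log units) apart, beyond the scatter of two such steps. The two changes therefore do not add up in this set of four compounds, though this rests on a single square in a single assay and shows neither why the steps differ nor how the change would behave on any other core.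

The compounds shown leave open whether the loss of the step follows the 4-methoxyphenyl group itself or the move away from 2-fluorophenyl, a question that 4-fluorophenyl or 2-methoxyphenyl on the same chain carbon would help to settle. They also leave open how other groups on the carbonyl carbon, such as dimethylamino or pyrrolidine, would behave on either core.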